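The source may hold more compounds than are shown below. What is called first, only, known or untested is meant among the compounds shown, and "the series" means these compounds.

Measured so far in a functional assay, read by spectrophotometry, with a stated time of 1 h; on this read-out lower numbers stand for stronger inhibition and higher numbers for weaker inhibition:
compound 1 `N/N=C\c1cc(=O)oc2cc(OCc3ccccc3)cc(OCc3ccccc3)c12`: > 2000000 nM, a limit of the assay
compound 2 `O=c1cc(/C=N\O)c2c(OCc3ccccc3)cc(OCc3ccccc3)cc2o1`: "not active" (no number reported)
compound 3 `O=c1cc(/C=N\c2ccc(O)cc2)c2c(OCc3ccccc3)cc(OCc3ccccc3)cc2o1`: 107000 nM

Compound 1 stands at the limit of > 2000000 nM in this assay, at which 1 of the 3 values shown sits, and this is a limit rather than a measured number. Compound 2 likewise returns no number in this assay. Among the measured compounds shown here, the one measured step that bears on the change ahead is an at least 18-fold lower number from compound 1 to compound 3 (1.27 log units; beyond the scatter), which came with 4-hydroxyphenyl in place of amino on a double-bonded nitrogen. Compound 4 `O=c1cc(/C=N\Nc2ccc([N+](=O)[O-])cc2[N+](=O)[O-])c2c(OCc3ccccc3)cc(OCc3ccccc3)cc2o1` differs from compound 1 by 2,4-dinitrophenyl in place of hydrogen on an amine nitrogen. Since compound 1 itself offers only a limit, the size of any drop can be expected only loosely. Compound 4 is nonetheless expected to show an at least 10-fold lower number from compound 1 to compound 4 (1.00 log units; beyond the scatter). The estimate for compound 4 in this assay is 200000 nM, between 30000 nM and 2000000 nM.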

Compound 4, half-maximal inhibitory concentration: 734000 nM
Compound 4: the middle estimate sits 3.7-fold (0.56 log units) below what was measured; the measured number falls inside the stated range.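

On the amine nitrogen, 2,4-dinitrophenyl in place of hydrogen brings an at least 2.7-fold lower number from compound 1 to compound 4 (0.43 log units; beyond the scatter) in this assay. This shows that substitution on this nitrogen itself, and not only replacement of the amino group as in compound 3, can return a measured number. Compound 1 holds only a limit, so the full size of this step stays unfixed: the limit of > 2000000 nM in this assay, at which 1 of the 4 values shown sits.

The compounds shown leave open whether a plain phenyl or a 4-nitrophenyl on this amine nitrogen would do the same. They also leave open whether an acetyl group, which has no aromatic ring, would.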